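A phenyl on the saturated ring carbon of compound 2

The source may hold more compounds than are shown below. What is called first, only, known or untested is meant among the compounds shown, and "the series" means these compounds.

The shared core carries a carboxymethyl group on a five-membered non-aromatic ring with one nitrogen. Compound 1 `O=C(O)C[C@H]1CCCN1c1ccc(OCc2ccc(Cl)cc2Cl)cc1` gives in a functional assay on cells for agonist activity at Free fatty acid receptor 1 (Mus musculus), read by FLIPR and calcium flux, with a stated time of 100 s (on this read-out higher numbers stand for an effect only at larger amounts of compound and lower numbers for an effect already at smaller amounts), only a limit, > 17000 nM. Compound 2 `Cc1ccccc1Cc1ccc(N2CCC[C@H]2CC(=O)O)cc1` likewise reaches only a limit in this assay, > 33000 nM; on the numbers shown it therefore stands without a measured value, and one further value of the three is a limit as well. Compound 3 `Cc1ccccc1Cc1ccc(N2CC[C@H](C)[C@H]2CC(=O)O)cc1` gives in this assay 1900 nM. Within the data shown here, the one measured step, an at least 17-fold lower number from compound 2 to compound 3 (1.23 log units; beyond the scatter), puts a methyl on a saturated ring carbon. Compound 4 `Cc1ccccc1Cc1ccc(N2C[C@@H](c3ccccc3)C[C@H]2CC(=O)O)cc1` differs from compound 2 by phenyl in place of hydrogen on a saturated ring carbon. Among the measured compounds shown here, only the step from compound 2 to compound 3 bears on this change; it was large, yet its group is a methyl and sits on another saturated ring carbon, so a step of that size is not assured. A gain beyond the scatter is expected, an at least 5.5-fold lower number from compound 2 to compound 4 (0.74 log units; beyond the scatter), though a smaller one. Compound 4 is estimated in this assay at 6000 nM, within 1500 nM to 30000 nM.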

Compound 4, half-maximal effective concentration: > 33000 nM
Compound 4: no number, only a limit (the forecaster's own chance of this, stated with the estimate: 30%); middle value at least 5.5-fold (0.74 log units) from the limit.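

In this assay compound 4 gives only a limit, > 33000 nM. Compound 2 also gives only a limit, > 33000 nM, so no step can be read between these two compounds. The compounds shown leave open what phenyl in place of hydrogen on this saturated ring carbon does to the read-out.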